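Tert-butyl on the fused ring: compound 4 from compound 3

The compounds below may be only part of what the source reports. "The series", "measured", "known", "first", "only" and "open" are said of these compounds alone.

Measured so far in a functional assay on MDA-MB-231 cells (Homo sapiens) for antiproliferative activity, read by fluorescence and SYBR Green assay, with a stated time of 24 h; a higher number here means a weaker inhibitor, a lower number a stronger inhibitor:
compound 1, `COc1ccc2c(c1)CCCN2S(=O)(=O)c1ccc(N2CCCC2=O)cc1`, gives 20 nM
compound 2, `Cc1ccc2c(c1)CCCN2S(=O)(=O)c1ccc(N2CCCC2=O)cc1`, gives 17 nM
compound 3, `O=C1CCCN1c1ccc(S(=O)(=O)N2CCCc3ccccc32)cc1`, gives 15 nM

Compound 3 carries the lowest of the three numbers, but the steps of a 1.3-fold lower number from compound 1 to compound 3 (0.12 log units; within the scatter), a 1.1-fold lower number from compound 2 to compound 3 (0.05 log units; within the scatter) and a 1.2-fold lower number from compound 1 to compound 2 (0.07 log units; within the scatter) all lie within the scatter, so no order among the three can be read from them.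

Compound 4, `CC(C)(C)c1ccc2c(c1)CCCN2S(=O)(=O)c1ccc(N2CCCC2=O)cc1`, differs from compound 3 by tert-butyl in place of hydrogen on an aromatic carbon. Among the compounds with values here, the steps that bear on this change are the two at the same aromatic carbon: methoxy and methyl there gave numbers indistinguishable from hydrogen in this assay. Within the data shown here, no measured compound carries tert-butyl at this carbon, so the expectation rests on those two steps alone, and a step of a 1.3-fold higher number from compound 3 to compound 4 (0.12 log units; within the scatter) within the scatter is expected. Compound 4 is therefore estimated at 20 nM, with a range from 8 nM to 55 nM.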

Compound 4, half-maximal inhibitory concentration: 608 nM
For compound 4 the middle estimate is 30-fold (1.48 log units) below the measured one, outside the stated range (above it).
By their numbers in this assay, from the lowest: compounds 3, 2 and 1 (each within the scatter of the next); then compound 4.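

In this assay this aromatic carbon proves sensitive to its substituent: hydrogen, methyl and methoxy read alike, yet tert-butyl stands well apart against hydrogen (a 41-fold higher number from compound 3 to compound 4 (1.61 log units; beyond the scatter)), against methyl (a 36-fold higher number from compound 2 to compound 4 (1.55 log units; beyond the scatter)) and against methoxy (a 30-fold higher number from compound 1 to compound 4 (1.48 log units; beyond the scatter)). Within the data shown here, the tolerance seen with the earlier compounds therefore does not extend to tert-butyl, with its 4 heavy atoms. Nothing available here bears on the reason for this rise.

Going by these compounds, whether ethyl or isopropyl at this carbon still reads like hydrogen remains open. So does the effect of an amine or a carboxylic acid there.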